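The source may hold more compounds than are shown below. What is called first, only, known or untested is meant among the compounds shown, and "the series" means these compounds.

In a functional assay on NCI-H460 cells (Homo sapiens) for cytotoxicity, read by MTT assay, with a stated time of 72 h (on this read-out higher numbers stand for weaker inhibition and lower numbers for stronger inhibition), compound 3 `CN(C)Cc1ccc2nc(NC(=O)N/N=C/c3c[nH]c4ccccc34)sc2c1` gives 2550 nM. That value lies within the scatter of compound 2 `CC1CCN(Cc2ccc3nc(NC(=O)N/N=C/c4c[nH]c5ccccc45)sc3c2)CC1` at 4130 nM, and both numbers are well above that of compound 1 `CC1CCN(Cc2ccc3nc(NC(=O)N/N=C/c4cn(Cc5cccc(Cl)c5)c5ccccc45)sc3c2)CC1` at 280 nM.

Compound 4 `CN(C)Cc1ccc2nc(NC(=O)N/N=C/c3cn(Cc4ccc(Cl)cc4)c4ccccc34)sc2c1` differs from compound 3 in one place: 4-chlorobenzyl in place of hydrogen on an aromatic nitrogen. In words, 4-chlorobenzyl stands in place of hydrogen on an aromatic nitrogen.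

The closest measured change is a 15-fold higher number from compound 1 to compound 2 (1.17 log units; beyond the scatter), a large step that takes a 3-chlorobenzyl group off an aromatic nitrogen. Read in reverse, it points to a large fall in the number when a chlorobenzyl group is added. The other measured change, a 1.6-fold lower number from compound 2 to compound 3 (0.21 log units; within the scatter), stays within the scatter, so the dimethylamino group of compound 3 gives no clear reason to expect a different outcome.

A large step towards stronger inhibition is therefore expected in this assay. Among the measured compounds shown here, only one pair supports this, and its chlorobenzyl group is not the same one, so the range stays wide. The estimated step is a 14-fold lower number from compound 3 to compound 4 (1.15 log units; beyond the scatter). The expected value for compound 4 is 180 nM, within an estimated range of 55 nM to 600 nM.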

Compound 4, half-maximal inhibitory concentration: 290 nM
Estimate against measurement, compound 4: 1.6-fold (0.21 log units) below; the range from low to high includes it.
By their numbers in this assay, from the lowest: compounds 1 and 4 (each within the scatter of the next); then compounds 3 and 2 (each within the scatter of the next).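

Compound 4 shows that placing a chlorobenzyl group on this aromatic nitrogen also lowers the number in this assay when the side chain carries dimethylamino rather than 4-methylpiperidin-1-yl (an 8.8-fold lower number from compound 3 to compound 4 (0.94 log units; beyond the scatter)). Among the compounds shown here, until now, the only evidence at this position was the single step for 3-chlorobenzyl (a 15-fold higher number from compound 1 to compound 2 (1.17 log units; beyond the scatter)). Both steps lie beyond the scatter, so across these two pairs the gain does not depend on one side-chain amine or on one chlorine placement.

On these data alone, what remains open is whether the chlorine matters at all, as benzyl without chlorine, a small methyl group or a longer alkyl chain on this nitrogen could settle that. The 3-chlorobenzyl and 4-chlorobenzyl groups also sit on compounds with different amines, so their effects cannot be ranked, and nothing shown here explains the gain.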